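Working notes: one open step in a small quinone-type series

A few compounds are considered here, and "the series" means these few. Any claim that something is new, unique, unknown or untested is made for them only; others in the source may bear on it.

Compound 1, `CCCC1=C(N2CC2)C(=O)C(C(COC(N)=O)OC)=C(N2CC2)C1=O`, gives 5.63 in a functional assay on L1210 cells (Mus musculus), with a stated time of 12 days; a higher number here means a more potent compound, by a factor of ten per unit of this negative logarithm, a lower number a less potent compound. Compound 2, `CC1=C(N2CC2)C(=O)C(Cc2ccccc2)=C(N2CC2)C1=O`, gives 4.85 in this assay. Compound 3, `CCOC(COC(N)=O)C1=C(N2CC2)C(=O)C(C)=C(N2CC2)C1=O`, gives 6.18 in this assay.

Compound 2 stands lowest of the three numbers; compound 1 lies beyond the scatter above it, and compound 3 lies further above still. For the measured compounds named here, no pair among the measured compounds differs in one place, so no single step can be read from them.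

Compound 4, `CC1=C(N2CC2)C(=O)C(C(C)C)=C(N2CC2)C1=O`, differs from compound 2 by isopropyl in place of benzyl on a double-bonded ring carbon. The rest of the shared core is unchanged. The step of a number 0.15 log units higher from compound 2 to compound 4 (within the scatter) is expected to be small, with no clear direction beyond the scatter. Compound 4 is estimated at 5, within the range 4.4 to 5.6.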

Compound 4, logarithm of the reciprocal of the active concentration, log(1/C): 5.6
Beside the measured number, compound 4's estimate is 0.60 log units below it, within the range that was stated.
By their numbers in this assay, from the lowest: compound 2; then compounds 4 and 1 (each within the scatter of the next); then compound 3.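

Isopropyl in place of benzyl gives a number 0.75 log units higher from compound 2 to compound 4 (beyond the scatter) and is the first single change readable in the series. In this assay, the number therefore depends on the group at this double-bonded ring carbon, and here the benzyl group's aromatic ring is absent from the compound with the higher number. Nothing available explains this step.

For the compounds shown here, with only this pair, the result cannot be separated into an effect of losing the ring and an effect of the smaller group. From the compounds shown here alone, how an ethyl group, a longer chain such as n-butyl, or an amine would read at this carbon remains open.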